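Amide-nitrogen substituent exchange in the shared-core series

The compounds below may be only part of what the source reports. "The series", "measured", "known", "first", "only" and "open" are said of these compounds alone.

Measured compounds:
compound 1, `O=C(COc1ccc2cc(/C=C3/SC(=O)NC3=O)ccc2c1)Nc1ccc([N+](=O)[O-])cc1`: 4000 nM
compound 2, `O=C(COc1ccc2cc(/C=C3/SC(=O)NC3=O)ccc2c1)Nc1ccc(F)cc1`: 6600 nM

In an assay on isolated protein for inhibition of histone deacetylase 8 (Homo sapiens), with a stated time of 1 h (a lower number here means a stronger inhibitor, a higher number a weaker inhibitor), compound 1 gives 4000 nM and compound 2 gives 6600 nM. Among the compounds with values here, the single measured step, a 1.7-fold higher number from compound 1 to compound 2 (0.22 log units; within the scatter), exchanges fluoro for nitro on an aromatic carbon and does not separate the two compounds; compound 2 therefore stands beside compound 1 with no established order between them.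

Compound 3, `Cc1cc(NC(=O)COc2ccc3cc(/C=C4/SC(=O)NC4=O)ccc3c2)no1`, is not yet measured. Its difference from compound 2 is 5-methyl-1,2-oxazol-3-yl in place of 4-fluorophenyl on an amide-type nitrogen. Within the data shown here, the one measured step bears on it only loosely: it altered a substituent on the ring carried by the amide-type nitrogen, whereas here the whole ring is exchanged for a five-membered aromatic ring with two hetero atoms. Among the measured compounds shown here, that step was within the scatter, and no measured step replaces the ring itself, so nothing in the data points in a definite direction. The expected step in this assay is a 1.1-fold higher number from compound 2 to compound 3 (0.03 log units; within the scatter), with a wide uncertainty. Compound 3 is therefore estimated at 7000 nM, with a range from 2500 nM to 20000 nM.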

Compound 3, half-maximal inhibitory concentration: > 50000 nM
Compound 3: no number, only a limit; the forecaster's own chance of this, stated with the estimate: 15%; at least 7.1-fold (0.85 log units) between middle value and limit.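

The result for compound 3 in this assay is a limit of the assay and not a number: the limit of > 50000 nM in this assay, at which 1 of the 3 values shown sits.

The group on the amide-type nitrogen is therefore not a free position: exchanging the whole ring gives an at least 7.5-fold higher number from compound 2 to compound 3 (0.87 log units; beyond the scatter) and an at least 12-fold higher number from compound 1 to compound 3 (1.09 log units; beyond the scatter), both beyond the scatter, whereas exchanging the substituent on the phenyl ring gave only a 1.7-fold higher number from compound 1 to compound 2 (0.22 log units; within the scatter), within the scatter. Within the data shown here, the earlier pair showed tolerance only for fluoro and nitro on a retained six-membered aromatic ring of carbon only; the 5-methyl-1,2-oxazol-3-yl group is the first exchange on this nitrogen to weaken inhibition clearly, and both new steps are lower bounds, so the full size of the loss stays unknown.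

The compounds shown do not separate the parts of this exchange, as the five-membered ring, its two hetero atoms and its methyl group all enter together. As far as these compounds go, an unsubstituted 1,2-oxazol-3-yl, a pyridinyl ring or a plain phenyl on the same nitrogen would be needed to place the loss, and the effect of an amine or a carboxylic acid on the phenyl ring remains open.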